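Replacing 1-phenylethyl with 3-methylphenyl on the shared core

The source may report more compounds than this note shows. Statements on the series, on what has been measured and on what is new or still open speak of the compounds shown alone.

In a physicochemical assay for solubility, with a stated time of 24 h, tested at 30 mg/mL (a lower number here means a less soluble compound, a higher number a more soluble compound), compound 1 `C[C@@H](Nc1c(NCCCCCC(=O)NO)c(=O)c1=O)c1ccccc1` gives 39000000 nM, and compound 2 `C[C@H](Nc1c(NCCCCCC(=O)NO)c(=O)c1=O)c1ccccc1` gives 28000000 nM. Compound 3 `Cc1ccc([C@H](C)Nc2c(NCCCCCC(=O)NO)c(=O)c2=O)cc1` gives 5600000 nM. Compound 2 therefore stands level with compound 1 at the top of these three numbers, with compound 3 clearly lower.

The next case is compound 4 `Cc1cccc(Nc2c(NCCCCCC(=O)NO)c(=O)c2=O)c1`, which has 3-methylphenyl in place of 1-phenylethyl on a nitrogen on an aromatic ring.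

Among the measured compounds shown here, two measured steps bear on this change. The first is a 1.4-fold lower number from compound 1 to compound 2 (0.14 log units; within the scatter), and it rests on (the fact that compounds 1 and 2 differ only in the configuration as drawn), so losing the defined stereocentre is expected to matter little. The second is a 5.0-fold lower number from compound 2 to compound 3 (0.70 log units; beyond the scatter), with methyl in place of hydrogen on an aromatic carbon, and compound 4 also carries a methyl on its aromatic ring. On the strength of that second step, the expected change is a 4.7-fold lower number from compound 2 to compound 4 (0.67 log units; beyond the scatter) in this assay, a lower number of modest size. For compound 4 the estimated value is 6000000 nM, with an expected range of 1500000 nM to 20000000 nM.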

Compound 4, solubility: 11000000 nM
For compound 4 the middle estimate is 1.8-fold (0.26 log units) below the measured one, and the stated range covers the measured number.
By their numbers in this assay, from the lowest: compounds 3 and 4 (each within the scatter of the next); then compounds 2 and 1 (each within the scatter of the next).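

Among the compounds shown here, at this place, on a nitrogen on an aromatic ring, the whole group changes for the first time, not just its configuration or a ring methyl: in this assay, 3-methylphenyl in place of 1-phenylethyl gives a 2.5-fold lower number from compound 2 to compound 4 (0.41 log units; beyond the scatter) and a 3.5-fold lower number from compound 1 to compound 4 (0.55 log units; beyond the scatter). Both steps lie beyond the scatter and run the same way, so the drop does not hang on which drawn form of 1-phenylethyl serves as the reference: the fact that compounds 1 and 2 differ only in the configuration as drawn. The earlier pair showed configuration alone leaving the number within the scatter, whereas replacing the group itself moves it.

This change alters the chain carbon, the stereocentre and the ring methyl together, and the compounds shown do not separate them. Going by these compounds, whether an amine or a carboxylic acid on the aromatic ring at this place would restore the higher numbers stays open.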